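Methoxy count on the shared core: two measured, one pending

The source may report more compounds than this note shows. Statements on the series, on what has been measured and on what is new or still open speak of the compounds shown alone.

Measured in a functional assay on RXF 393 cells (Homo sapiens) for inhibition, read by sulforhodamine B assay, with a stated time of 48 h; a lower number here means a stronger inhibitor of growth, a higher number a weaker inhibitor of growth:
compound 1 `COc1ccc(-c2cc(/C=C/C(=O)c3ccc(N)cc3)[nH]n2)cc1` gives 4190 nM
compound 2 `COc1cc(-c2cc(/C=C/C(=O)c3ccc(N)cc3)[nH]n2)cc(OC)c1OC` gives 3240 nM

Compound 2 holds the lowest of the two numbers in this assay; its nearest neighbour is compound 1, whose number is higher by a margin that lies within the scatter, so no order between the two can be read. Among the measured compounds shown here, no pair in this set differs in one place, so there is no measured step to guide the next move.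

Compound 3 `COc1ccc(-c2cc(/C=C/C(=O)c3ccc(N)cc3)[nH]n2)cc1OC` is the unmeasured member. From compound 2 it differs by hydrogen in place of methoxy on an aromatic carbon. The change removes one of the three methoxy groups while keeping the two others; with compound 1, which carries a single methoxy, sitting within the scatter of compound 2, nothing in the set points to a move in either direction, and the step of a 1.1-fold higher number from compound 2 to compound 3 (0.05 log units; within the scatter) is expected to be none beyond the scatter. Compound 3 is therefore estimated at 3600 nM, with a range from 1800 nM to 7500 nM.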

Compound 3, concentration for total growth inhibition: 5120 nM
For compound 3 the middle estimate is 1.4-fold (0.15 log units) below the measured one, within the range that was stated.
By their numbers in this assay, from the lowest: compounds 2, 1 and 3 (each within the scatter of the next).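

Hydrogen in place of methoxy on the aromatic carbon ortho to a methoxy group and meta to a large group now has a measured step in this assay: a 1.6-fold higher number from compound 2 to compound 3 (0.20 log units; within the scatter), and methoxy in place of hydrogen on an aromatic carbon gives a 1.2-fold higher number from compound 1 to compound 3 (0.09 log units; within the scatter). Among the compounds shown here, these are the first comparisons that differ in one place, and both lie within the scatter, so the single methoxy change cannot be read as altering growth inhibition in either direction. No measurement on hand offers an explanation for this result.

Open, as far as these compounds go, is whether a hydroxyl, a chlorine or a longer alkoxy chain such as ethoxy on this aromatic carbon would give a step beyond the scatter. The compounds shown also all carry the same amine, so what a carboxylic acid in its place would do remains an open question.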